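Fluoro in Place of Hydrogen Ortho to a Methyl Group

A few compounds are considered here, and "the series" means these few. Any claim that something is new, unique, unknown or untested is made for them only; others in the source may bear on it.

Compound 1 `Fc1cc2nc(-c3cccnc3)n(C3CC3)c2cc1F`: 2.1 nM
Compound 2 `Cc1ccncc1-c1nc2cc(F)c(F)cc2n1C1CC1`: 10.2 nM

In an assay on V79 cells for inhibition of cytochrome P450 11B2, mitochondrial (Homo sapiens), read by HTRF, with a stated time of 1 h (a higher number here means a weaker inhibitor, a lower number a stronger inhibitor), compound 1 gives 2.1 nM, and compound 2 gives 10.2 nM. Among the measured compounds shown here, the one step between them, a 4.9-fold higher number from compound 1 to compound 2 (0.69 log units; beyond the scatter), went with a methyl in place of hydrogen on an aromatic carbon. Compound 2 thus holds the higher of the two numbers, with compound 1 the nearest neighbour.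

Compound 3 `Cc1c(F)cncc1-c1nc2cc(F)c(F)cc2n1C1CC1` differs from compound 2 in one place: fluoro in place of hydrogen on an aromatic carbon. The fluoro enters on an aromatic carbon of a six-membered aromatic ring with 1 nitrogen, ortho to a methyl group and two atoms from the ring nitrogen. For the measured compounds named here, no measured step involves a fluoro entering anywhere, so the only step known, the methyl step, gives no direct guide. The expectation is therefore a step no larger than the scatter, a 1.0-fold lower number from compound 2 to compound 3 (0.01 log units; within the scatter), in either direction. Compound 3 is estimated to give 10 nM in this assay, within a range from 3 nM to 35 nM.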

Compound 3, half-maximal inhibitory concentration: 0.5 nM
Compound 3: middle estimate off by 20-fold (1.30 log units), on the high side; the measured number lies below the stated range.
By their numbers in this assay, from the lowest: compound 3; then compound 1; then compound 2.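

In this assay fluoro in place of hydrogen gave a 20-fold lower number from compound 2 to compound 3 (1.31 log units; beyond the scatter) and so made a far stronger inhibitor, which shows that this one carbon, ortho to a methyl group and two atoms from the ring nitrogen, has a large bearing on the result. Among the compounds shown here, the only earlier step on this ring, a 4.9-fold higher number from compound 1 to compound 2 (0.69 log units; beyond the scatter), went with a methyl group and ran the opposite way, so across these compounds a single added heavy atom on this ring can move the number markedly in either direction. The data shown offer no measurement that explains the size of the fluoro step.

As far as these compounds go, it remains open whether fluoro would give a step of this size without the neighbouring methyl group. Also open, from the compounds shown here alone, is how chloro, methoxy or nitrile would compare with fluoro on this same carbon.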